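Flipping One Ring Centre: What Cell Tolerance to Expect

The source may report more compounds than this note shows. Statements on the series, on what has been measured and on what is new or still open speak of the compounds shown alone.

Compound 2 `CC(C)c1c(O[C@H]2CCCC[C@@H]2C)cc(CCc2ccccc2)[nH]c1=O` was tested in an ADME assay on MT4 cells (Homo sapiens) for cytotoxicity, read by XTT assay, with a stated time of 3 days; a lower number here means that less compound is tolerated, a higher number that more compound is tolerated. In this assay compound 2 gives only a limit, > 300000 nM, rather than a number. That is the limit of > 300000 nM in this assay, at which 1 of the 3 values shown sits, so on the numbers shown compound 2 stands at the edge of what the measurement reports. Two related compounds carry real numbers. Compound 1 `CC(C)c1c(OC2CCCCC2C)cc(Cc2ccc(F)cc2)[nH]c1=O`, drawn without a fixed configuration at its ring, gives 64600 nM in this assay. Compound 3 `CC(C)c1c(Cc2ccccc2)n(COCc2ccccc2)c(=O)[nH]c1=O`, built on a different core, gives 84600 nM in this assay. Compound 4 `CC(C)c1c(O[C@H]2CCCC[C@H]2C)cc(CCc2ccccc2)[nH]c1=O` has not yet been measured. Its relation to compound 2 is this: the two compounds have the same atoms and bonds and differ only in configuration as drawn: 1 of 2 stereo elements differ; a stereocentre at a saturated ring carbon is drawn S in compound 2 and R in compound 4. Nothing leaves and nothing enters; the two compounds have the same atoms and bonds and differ only in configuration as drawn, with a stereocentre at a saturated ring carbon drawn S in compound 2 and R in compound 4. Within the data shown here, no measured pair differing in one place is at hand, so the usual size of such a step is unknown here. Because compound 2 sits at > 300000 nM, the true step cannot be read as a number. A step of no more than the usual scatter is expected, an at least 1.5-fold lower number from compound 2 to compound 4 (0.17 log units; that floor lies within the scatter). Compound 4 is estimated at 200000 nM in this assay, within a range from 60000 nM to 350000 nM.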

Compound 4, half-maximal cytotoxic concentration: 87900 nM
The estimate for compound 4 lay 2.3-fold (0.36 log units) above the measured number, within the range that was stated.
By their numbers in this assay, from the lowest: compounds 1, 3 and 4 (each within the scatter of the next). At a limit, above all of these: compound 2.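

In this assay, among these compounds, the earlier compounds could not show whether configuration at this saturated ring carbon matters, since none of them formed a pair differing in one place. Compounds 2 and 4 now form such a pair, and the change of one stereocentre from S to R gives an at least 3.4-fold lower number from compound 2 to compound 4 (0.53 log units; beyond the scatter), so cell tolerance responds to the way this one centre is drawn, with no group added or removed: the fact that compounds 2 and 4 differ only in the configuration as drawn. From the compounds shown here alone, compound 2 gives only a limit of the assay, so this step is a floor and its true size remains unknown: the limit of > 300000 nM in this assay, at which 1 of the 4 values shown sits.

The compounds shown leave open whether changing the second stereocentre, drawn alike in compounds 2 and 4, would also shift the number in this assay. They also leave open whether changing this ring centre gives a step of similar size in a compound on the same core that also carries an amine or a carboxylic acid.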